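Ethyl to cyclopropyl on compound 1

This account rests on a few compounds, and the source may have more. Where it says the series, first, only, none or still open, it means among the compounds named here.

compound 1 `CCN1C(=O)CN(Cc2ccc(-c3cccc(CN4CCCCC4)n3)cc2)C1=O` gives 8.8
compound 2 `CCN1C(=O)CN(Cc2ccc(-c3ccc(F)c(CN4CCCCC4)n3)cc2)C1=O` gives 8.5

Going by the values given here, in a physicochemical assay for acid dissociation, compound 1 gives 8.8 and lies within the scatter of compound 2, the only other measured compound. Compound 3 `O=C1CN(Cc2ccc(-c3cccc(CN4CCCCC4)n3)cc2)C(=O)N1C1CC1` is still unmeasured. It carries cyclopropyl in place of ethyl on an amide-type nitrogen in a ring. Among the compounds with values here, the one measured step is a change of another kind, fluoro in place of hydrogen on an aromatic carbon (a number 0.30 log units lower from compound 1 to compound 2 (within the scatter)). Within the data shown here, no measured step covers the new change, so no shift beyond the scatter is expected in this assay. The estimated step is no change at the digits printed from compound 1 to compound 3 (within the scatter) and stays within the scatter. For compound 3 the expected value is 8.8 (estimated range 8.5 to 9.1).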

Compound 3, acid dissociation constant: 9
Beside the measured number, compound 3's estimate is 0.20 log units below it, and the stated range covers the measured number.
By their numbers in this assay, from the lowest: compounds 2, 1 and 3 (each within the scatter of the next, the first and the last beyond it).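

Going by these compounds alone, until now the only step was on an aromatic carbon, so this is the first reading at the amide-type nitrogen in a ring. In this assay, cyclopropyl in place of ethyl gives a number 0.20 log units higher from compound 1 to compound 3 (within the scatter), so adding the three-membered carbon ring leaves the number within the usual spread of repeats at this position. No supporting data bear on why this is so. Still open, on these data alone, is whether a butyl chain or a group carrying a carboxylic acid on this nitrogen would move the number beyond the scatter.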